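The source may hold more compounds than are shown below. What is called first, only, known or untested is meant among the compounds shown, and "the series" means these compounds.

Working notes on the series. Of the compounds shown here, two have been measured in a functional assay on U-373MG ATCC cells (Homo sapiens) for inhibition, read by MTT assay, with a stated time of 72 h; on this read-out higher numbers stand for weaker inhibition and lower numbers for stronger inhibition. Compound 1 `CC1(C)CC(NC(=S)Nc2cccc(C#N)c2)c2cc(Cl)ccc2O1` gives 7000 nM and stands highest of the two numbers. The nearest is compound 2 `CC1(C)CC(NC(=S)Nc2cccc([N+](=O)[O-])c2)c2cc(Cl)ccc2O1`, which in this assay gives 3000 nM; the step between them, a 2.3-fold lower number from compound 1 to compound 2 (0.37 log units; beyond the scatter), came with nitro in place of cyano on an aromatic carbon.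

Compound 3 `CC1(C)CC(NC(=S)Nc2cccc(C#N)c2)c2cc(Br)ccc2O1` is not yet measured. It differs from compound 1 by bromo in place of chloro on an aromatic carbon. Within the data shown here, the single measured step concerns the cyano position and does not bear on an exchange of one halogen for another; no measured pair speaks to the chloro position at all. Compound 3 is therefore expected to give a step of no change at the digits printed from compound 1 to compound 3 (within the scatter), none beyond the scatter. The estimate for compound 3 in this assay is 7000 nM, with a range from 3000 nM to 16000 nM.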

Compound 3, half-maximal inhibitory concentration: 6000 nM
Compound 3: the middle estimate sits 1.2-fold (0.07 log units) above what was measured; the measured number falls inside the stated range.
By their numbers in this assay, from the lowest: compounds 2, 3 and 1 (each within the scatter of the next, the first and the last beyond it).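

The chloro position now has its first reading: in this assay, the exchange gives a 1.2-fold lower number from compound 1 to compound 3 (0.07 log units; within the scatter). Among these compounds, with the cyano group held fixed, the two halogens on this six-membered aromatic ring cannot be told apart, whereas the only earlier step, nitro in place of cyano, lay beyond the scatter. Nothing available explains this result, and the comparison rests on a single pair.

The compounds shown carry only chloro or bromo at this position, so the effect of an amine, a methoxy group or a carboxylic acid there remains open. Also open, from the compounds shown here alone, is whether bromo in place of chloro would give the same small step on the nitro compound 2, and so whether the two positions act independently.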